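Triazolyl in Place of Methylsulfanyl: Expected Clearance

The source may report more compounds than this note shows. Statements on the series, on what has been measured and on what is new or still open speak of the compounds shown alone.

Measured so far:
Compound 1 `CNc1nc(NC)nc(NC2(C#N)CCCCC2)n1`: 210 mL/min/kg
Compound 2 `CNc1nc(NC2(C#N)CCCCC2)nc(SC)n1`: 579 mL/min/kg

In an ADME assay on microsomes from liver (Rattus norvegicus) for metabolic stability (a higher number here means faster removal of the compound, a lower number slower removal), compound 2 stands highest of the two numbers; its nearest neighbour is compound 1, which gives 210 mL/min/kg. Within the data shown here, the single measured step, a 2.8-fold higher number from compound 1 to compound 2 (0.44 log units; beyond the scatter), lies beyond the scatter and is the only guide available.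

Compound 3 `CNc1nc(NC2(C#N)CCCCC2)nc(-n2cncn2)n1` differs from compound 2 by 1H-1,2,4-triazol-1-yl in place of methylsulfanyl on an aromatic carbon. Among the measured compounds shown here, the measured step concerns the same aromatic carbon of the shared core, but it exchanges methylamino for methylsulfanyl; no measured compound carries a 1H-1,2,4-triazol-1-yl group, so that step bears on the present change only in showing that this position is sensitive in this assay. With the group that gave the higher number leaving, compound 3 is expected to give a somewhat lower number than compound 2, a step of a 1.8-fold lower number from compound 2 to compound 3 (0.26 log units; within the scatter), though one that may well fall within the scatter. The estimate for compound 3 in this assay is therefore 320 mL/min/kg, with a range from 130 mL/min/kg to 750 mL/min/kg.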

Compound 3, clearance: 52 mL/min/kg
The estimate for compound 3 lay 6.2-fold (0.79 log units) above the measured number; the measured number lies below the stated range.
By their numbers in this assay, from the lowest: compound 3; then compound 1; then compound 2.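

In this assay, among these compounds, the aromatic carbon between two ring nitrogen atoms now proves able to carry a far larger change than the one earlier step showed, for 1H-1,2,4-triazol-1-yl in place of methylsulfanyl gives an 11-fold lower number from compound 2 to compound 3 (1.05 log units; beyond the scatter) and so moves the number well past the level of the methylamino group. The new group also compares favourably with that methylamino group, with a 4.0-fold lower number from compound 1 to compound 3 (0.61 log units; beyond the scatter) on the same carbon, so the low number of compound 3 is more than the loss of methylsulfanyl: among the three groups shown at this position, the triazolyl group gives the lowest number, then methylamino, then methylsulfanyl. Nothing measured here bears on what lies behind these steps.

The compounds shown leave open whether this low number belongs to the 1H-1,2,4-triazol-1-yl group in particular or would also appear with another ring at this carbon, such as a pyrazol-1-yl or imidazol-1-yl group. They also leave open whether the step would hold if the remaining methylamino group gave way to an ethylamino group.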